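Notes on a butanedioxy-linked benzoic acid series

A few compounds are considered here, and "the series" means these few. Any claim that something is new, unique, unknown or untested is made for them only; others in the source may bear on it.

Measured compounds:
compound 1, `Cc1c(OCCCCOc2ccc(C(=O)O)cc2Cl)ccc(C(=O)CC2CCCC2)c1O`: > 10000 nM
compound 2, `Cc1c(OCCCCOc2ccc(C(=O)O)cc2)ccc(C(=O)CC(C)C)c1O`: 2720 nM
compound 3, `COC(=O)c1ccc(OCCCCOc2ccc(C(=O)CC(C)C)c(O)c2C)cc1`: "not determined" (no result reported)

In an assay on HEK293 cells for positive allosteric modulation of metabotropic glutamate receptor 3 (Rattus norvegicus), read by thallium flux, with a stated time of 2.5 min (a higher number here means that more compound is needed for the effect, a lower number that less compound is needed), compound 2 gives 2720 nM. For compound 1 this assay returns a limit of the assay rather than a number, > 10000 nM; that limit is the limit of > 10000 nM in this assay, at which 1 of the 3 values shown sits. Compound 3 carries "not determined" (no result reported) in this assay, so it stands nowhere on the numbers shown and no step can be anchored on it.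

Compound 4, `Cc1c(OCCCCOc2ccc(C(=O)O)cc2Cl)ccc(C(=O)CC(C)C)c1O`, differs from compound 3 in one place: 4-carboxy-2-chlorophenyl in place of 4-(methoxycarbonyl)phenyl on an oxygen on a saturated carbon. Compound 3 has no number. No direction or size of step can therefore be given for this change. Compound 4 shares its aryloxy end with compound 1 and its ketone side chain with compound 2, and those two compounds show a limit and a number of moderate size.

For compound 4 in this assay the expected value is 6000 nM, estimated to fall between 2000 nM and 20000 nM, with a fair chance that only a limit is returned.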

Compound 4, half-maximal effective concentration: 1140 nM
For compound 4 the middle estimate is 5.3-fold (0.72 log units) above the measured one; the whole stated range lies above it.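

In this assay, chloro in place of hydrogen on an aromatic carbon gives a 2.4-fold lower number from compound 2 to compound 4 (0.38 log units; beyond the scatter), so this substitution on the 4-carboxyphenyl end does not cost activity when the ketone side chain carries isopropyl, which compound 1 alone could not show. Isopropyl in place of cyclopentyl on a saturated chain carbon bound to a carbonyl carbon gives an at least 8.7-fold lower number from compound 1 to compound 4 (0.94 log units; beyond the scatter), which ties the weak result of compound 1 to the cyclopentyl group and not to the chloro. The value of compound 1 in that step is a limit of the assay and not a number: the limit of > 10000 nM in this assay, at which 1 of the 4 values shown sits.

The change from compound 3 cannot be read, since compound 3 has no number, so the methyl ester and the carboxylic acid remain uncompared. Also open, on these data alone, is how fluoro or trifluoromethyl in place of the chloro, or a longer chain in place of the butanedioxy linker, would read in this assay.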